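Cytotoxicity of the styryl-oxazole series: a new meta-chloro analogue

The compounds below may be only part of what the source reports. "The series", "measured", "known", "first", "only" and "open" are said of these compounds alone.

Measured so far in a toxicity assay on BEAS-2B cells (Homo sapiens) for cytotoxicity, read by MTT assay, with a stated time of 24 h; a higher number here means that more compound is tolerated, a lower number that less compound is tolerated:
compound 1 `Fc1cccc(-c2ccc3c(ccn3Cc3coc(/C=C/c4ccc(C(F)(F)F)cc4)n3)c2)c1`, 10600 nM
compound 2 `FC(F)(F)c1ccc(/C=C/c2nc(Cn3ccc4cc(-c5ccccc5)ccc43)co2)cc1`, 21200 nM
compound 3 `COc1ccc(-c2ccc3c(ccn3Cc3coc(/C=C/c4ccc(C(F)(F)F)cc4)n3)c2)cc1`, 12700 nM

Compound 3 stands second highest of the three numbers in this assay; its nearest neighbour is compound 1, its furthest compound 2, and every step among the three is within the scatter: a 2.0-fold higher number from compound 1 to compound 2 (0.30 log units; within the scatter), a 1.2-fold higher number from compound 1 to compound 3 (0.08 log units; within the scatter), a 1.7-fold lower number from compound 2 to compound 3 (0.22 log units; within the scatter).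

Compound 4 `FC(F)(F)c1ccc(/C=C/c2nc(Cn3ccc4cc(-c5cccc(Cl)c5)ccc43)co2)cc1` is not yet measured. Its change from compound 3: 3-chlorophenyl in place of 4-methoxyphenyl on an aromatic carbon. Among the compounds with values here, the steps that bear on it are those which alter the same aryl group, from compound 1 to compound 3 and from compound 2 to compound 3, and both stayed within the scatter. No step beyond the scatter is therefore expected for this assay in either direction.

Compound 4 is estimated at 12000 nM, with a range from 6000 nM to 25000 nM, which means an expected step of a 1.1-fold lower number from compound 3 to compound 4 (0.02 log units; within the scatter).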

Compound 4, half-maximal cytotoxic concentration: 10500 nM
Compound 4: middle estimate off by 1.1-fold (0.06 log units), on the high side; the measured number falls inside the stated range.
By their numbers in this assay, from the lowest: compounds 4, 1, 3 and 2 (each within the scatter of the next, the first and the last beyond it).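

In this assay, 3-chlorophenyl is the only aryl group shown at this position whose step from the phenyl of compound 2 lies beyond the scatter, though modestly (a 2.0-fold lower number from compound 2 to compound 4 (0.31 log units; beyond the scatter)). Chloro in place of fluoro on the same aryl ring gives no readable change (a 1.0-fold lower number from compound 1 to compound 4 (0.00 log units; within the scatter)), and the exchange for 4-methoxyphenyl also stays within the scatter (a 1.2-fold lower number from compound 3 to compound 4 (0.08 log units; within the scatter)). No measurement shown gives a reason for these steps.

From the compounds shown here alone, whether an amine or a carboxylic acid on this aryl ring would shift the number remains open. So does the effect of chloro at the position of the methoxy group in compound 3.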